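The source may hold more compounds than are shown below. What is called first, only, known or untested is meant among the compounds shown, and "the series" means these compounds.

Compound 1 `COc1ccc(CNc2cc(OC)c(OC)c(OC)c2)cc1[N+](=O)[O-]` gives 16800 nM in a functional assay on KYSE-450 cells (Homo sapiens) for inhibition, read by MTT assay, with a stated time of 48 h; on this read-out lower numbers stand for stronger inhibition and higher numbers for weaker inhibition. Compound 2 `CCCCC(=O)N(Cc1ccc(OC)c(O)c1)c1cc(OC)c(OC)c(OC)c1` gives 300 nM in this assay. Compound 3 `COc1cc(NCc2ccc(Cl)cc2)cc(OC)c1OC` reaches only the limit of this assay, reported as > 80000 nM.

Of the two numbers that were obtained, compound 2 stands at the lower one. Its nearest neighbour is compound 1, whose number is higher by a gap beyond the usual scatter. Compound 3 sits at the limit of > 80000 nM in this assay, at which 1 of the 3 values shown sits, so it offers no number to set against the other two.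

Compound 4 `COc1ccc(CN(C(=O)CCCl)c2cc(OC)c(OC)c(OC)c2)cc1O` has not yet been measured in this assay. It differs from compound 2 in one place: chloro in place of ethyl on a saturated chain carbon, two bonds along the chain from a carbonyl carbon. The carbonyl and the rest of the shared core are unchanged; the chain on the carbonyl carbon is shortened and carries a chlorine in place of its ethyl end.

Among the measured compounds shown here, no pair of measured compounds that differ in a single place is available here, so the step has to be judged from compound 2 alone. The expected step from compound 2 to compound 4 is a 2.0-fold higher number from compound 2 to compound 4 (0.30 log units; within the scatter), a modest rise in the number, within or just beyond the scatter. On that basis compound 4 is expected to give about 600 nM in this assay, with a range from 150 nM to 3000 nM.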

Compound 4, half-maximal inhibitory concentration: 110 nM
Compound 4: the middle estimate sits 5.5-fold (0.74 log units) above what was measured; measured number outside the range, below it.
By their numbers in this assay, from the lowest: compound 4; then compound 2; then compound 1. At a limit, above all of these: compound 3.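

The change from ethyl to chloro, on a saturated chain carbon, two bonds along the chain from a carbonyl carbon, gives in this assay a 2.7-fold lower number from compound 2 to compound 4 (0.44 log units; beyond the scatter). This is the first comparison among the compounds shown that isolates a single place, and it shows that the butyl on the carbonyl can give way to 2-chloroethyl without any loss of inhibition in these cells; the number in fact falls by a modest step that lies beyond the usual scatter. None of the measurements shown gives a property of either chain that would account for this step.

The single step shortens the chain and brings in chlorine at once, so the compounds shown cannot say how much of the change belongs to the shorter chain and how much to the chlorine itself. On these data alone, it also remains open how a hydroxyl, an amine or a carboxylic acid at the end of this chain would read, and whether a longer chain ending in chlorine would follow the same direction in this read-out.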